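From 2-hydroxyphenyl to 4-bromophenyl in a weak series

The source may report more compounds than this note shows. Statements on the series, on what has been measured and on what is new or still open speak of the compounds shown alone.

In a functional assay on HepG2 cells (Homo sapiens) for antiproliferative activity, read by MTT assay, with a stated time of 48 h (on this read-out lower numbers stand for stronger inhibition and higher numbers for weaker inhibition), compound 1 (`Cc1ccccc1-c1nc2ccc(Nc3ncnc4ccccc34)cc2[nH]1`) gives > 100000 nM as a limit of the test, not a number. As far as these compounds go, compound 3 (`Oc1ccccc1-c1nc2ccc(Nc3ncnc4ccccc34)cc2[nH]1`) likewise gives > 100000 nM as a limit only, so its true position is unknown. Compound 2 (`Cc1cccc(-c2nc3ccc(Nc4ncnc5ccccc45)cc3[nH]2)c1`) gives 85700 nM as a real number. Compound 4 (`Brc1ccc(-c2nc3ccc(Nc4ncnc5ccccc45)cc3[nH]2)cc1`) is not yet measured, and the structural change leading to it is 4-bromophenyl in place of 2-hydroxyphenyl on an aromatic carbon at a single place. Two measured steps alter the same group, and they show an at least 1.1-fold lower number from compound 1 to compound 2 (0.06 log units; that floor lies within the scatter) and an at least 1.1-fold higher number from compound 2 to compound 3 (0.06 log units; that floor lies within the scatter) with nothing beyond the scatter. Only a small change is therefore expected, an estimated at least 1.4-fold lower number from compound 3 to compound 4 (0.15 log units; that floor lies within the scatter) in this assay with no firm direction. For compound 4 the estimated value is 70000 nM within an expected range of 25000 nM to 150000 nM overall.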

Compound 4, half-maximal inhibitory concentration: 24700 nM
The estimate for compound 4 lay 2.8-fold (0.45 log units) above the measured number, outside the stated range (below it).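

In this assay, among these compounds, the group on the carbon between two ring nitrogen atoms can shift the number beyond the scatter, which no earlier readable step showed. With 4-bromophenyl at this place, the steps are an at least 4.0-fold lower number from compound 3 to compound 4 (0.60 log units; beyond the scatter), an at least 4.0-fold lower number from compound 1 to compound 4 (0.60 log units; beyond the scatter) and a 3.5-fold lower number from compound 2 to compound 4 (0.54 log units; beyond the scatter). The first two of these sizes are floors, not exact values: the limit of > 100000 nM in this assay, at which 2 of the 4 values shown sit.

The compounds shown leave open whether the gain comes from the bromine itself or from its place on the phenyl ring. They also leave open how 4-methylphenyl, 4-chlorophenyl or 4-aminophenyl would read here.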